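Aryl variation on the hydrazone of a shared core

The compounds below may be only part of what the source reports. "The series", "measured", "known", "first", "only" and "open" are said of these compounds alone.

Three compounds sharing one core differ only in the aryl ring on the carbon with a double bond to nitrogen. In a functional assay on MCF7 cells (Homo sapiens) for inhibition, read by sulforhodamine B assay, with a stated time of 48 h (on this read-out lower numbers stand for stronger inhibition and higher numbers for weaker inhibition), compound 1 `CSc1nn(-c2ccccc2)c2ncnc(N/N=C/c3ccc(N)cc3)c12` gives 12 nM. Compound 2 `CSc1nn(-c2ccccc2)c2ncnc(N/N=C/c3ccc(Br)cc3)c12` gives 10.9 nM, and compound 3 `CSc1nn(-c2ccccc2)c2ncnc(N/N=C/c3ccccc3O)c12` gives 10.7 nM. Compound 3 carries the lowest of the three numbers, yet its gap to each of the others is within the scatter, so the three read as alike. The swaps a 1.1-fold lower number from compound 1 to compound 2 (0.04 log units; within the scatter), a 1.1-fold lower number from compound 1 to compound 3 (0.05 log units; within the scatter) and a 1.0-fold lower number from compound 2 to compound 3 (0.01 log units; within the scatter) all stay within the scatter.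

Compound 4 `COc1cccc(/C=N/Nc2ncnc3c2c(SC)nn3-c2ccccc2)c1` is not yet measured. From compound 3 the change is 3-methoxyphenyl in place of 2-hydroxyphenyl on a carbon with a double bond to nitrogen. The steps that exchanged the ring on that carbon bear directly on it, and none of them moved the number beyond the scatter. For compound 4 the expected step of a 1.0-fold higher number from compound 3 to compound 4 (0.01 log units; within the scatter) is therefore none beyond the scatter in this assay. Compound 4 is estimated at 11 nM in this assay, with a range from 5 nM to 25 nM.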

Compound 4, half-maximal inhibitory concentration: 11.1 nM
Beside the measured number, compound 4's estimate is 1.0-fold (0.00 log units) below it; measured number inside the range.
By their numbers in this assay, from the lowest: compounds 3, 2, 4 and 1 (each within the scatter of the next).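

In this assay, 3-methoxyphenyl on the carbon with a double bond to nitrogen stays within the scatter of all three earlier rings (a 1.0-fold higher number from compound 3 to compound 4 (0.02 log units; within the scatter)) (a 1.0-fold higher number from compound 2 to compound 4 (0.01 log units; within the scatter)) (a 1.1-fold lower number from compound 1 to compound 4 (0.03 log units; within the scatter)). The entering group has 0 hydrogen-bond donors and 8 heavy atoms, against 1 hydrogen-bond donor and 7 heavy atoms in 2-hydroxyphenyl, so this position now shows an oxygen-bearing ring without a hydrogen-bond donor giving a number alike to that of the hydroxy-bearing ring. No accompanying measurement accounts for this flat result.

Going by these compounds, all four compounds carry a six-membered aromatic ring of carbon only at this position, so a butyl chain or a morpholine there remains open, as does a carboxylic acid on the ring. On these data alone, the shared core stays fixed throughout, so how far the flat response extends beyond this one position also remains open.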